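The compounds below may be only part of what the source reports. "The series", "measured", "known", "first", "only" and "open" are said of these compounds alone.

Compound 1 `CC(C)N1C(=O)C(C2=NS(=O)(=O)c3cc(NS(C)(=O)=O)ccc3N2)=C(O)C2CCCC21`: in an ADME assay on Huh-7 cells (Homo sapiens) for cytotoxicity, with a stated time of 72 h (on this read-out higher numbers stand for lower toxicity in this test and lower numbers for higher toxicity in this test), compound 1 gives only a limit, > 33000 nM.
Compound 2 `CS(=O)(=O)Nc1ccc2c(c1)S(=O)(=O)N=C(C1=C(O)C3CCCC3N(CCC3CC3)C1=O)N2`: in this assay compound 2 gives only a limit, > 33000 nM.
Compound 3 `CS(=O)(=O)Nc1ccc2c(c1)S(=O)(=O)N=C(C1=C(O)C3CCCC3N(Cc3ccccc3)C1=O)N2`: in this assay compound 3 gives only a limit, > 33000 nM.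

Compound 3 stands nowhere apart from the other two: each of the three values is a limit of this assay and not a number, as the limit of > 33000 nM in this assay, at which 3 of the 3 values shown sit, records. The compound that follows, compound 4 `CS(=O)(=O)Nc1ccc2c(c1)S(=O)(=O)N=C(C1=C(O)C3CCCC3N(CC3CCC3)C1=O)N2`, differs from compound 3 by cyclobutyl in place of phenyl on a saturated chain carbon bound to an amide-type nitrogen in a ring. The measured steps that touch the group on the amide-type nitrogen in the ring are a step that the two limits leave unreadable from compound 1 to compound 2, a step that the two limits leave unreadable from compound 1 to compound 3 and a step that the two limits leave unreadable from compound 2 to compound 3; none of them can be read, because every pair sits at the limit of > 33000 nM in this assay, at which 3 of the 3 values shown sit. These steps therefore give neither a direction nor a size, and the change from phenyl to cyclobutyl on the saturated chain carbon is of the same kind as the unreadable ones. The step from compound 3 to compound 4 is expected to be a step that the limit leaves unreadable from compound 3 to compound 4, nothing beyond the scatter. Compound 4 is thus expected to give 50000 nM in this assay, within 25000 nM to 150000 nM, most probably reported once more only as a limit.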

Compound 4, half-maximal cytotoxic concentration: > 33000 nM
Compound 4 was reported as a limit; the forecaster's own chance of this, stated with the estimate: 90%; the middle value is on the limit's open side.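

No step among compound 1, compound 2, compound 3 and compound 4 can be read in this assay, because each compound gives only a limit: the limit of > 33000 nM in this assay, at which 4 of the 4 values shown sit.

The compounds shown leave open where the half-maximal cytotoxic concentration of any of the four lies, and whether the group on the amide-type nitrogen in the ring changes it at all.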